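Azide to Amine: Compound 1 Toward Compound 4

The compounds below may be only part of what the source reports. "The series", "measured", "known", "first", "only" and "open" are said of these compounds alone.

Compound 1 `CCCCCCCCCO[C@@H]1[C@@H](N)[C@@H](OC[C@H](O)CN=[N+]=[N-])O[C@H](CN)[C@H]1OCCCCCCCCC` was tested in a toxicity assay on the whole organism (J774 cells) for cytotoxicity, with Mus musculus as the target, read by MTT assay, with a stated time of 24 h, tested at 30 uM (on this read-out higher numbers stand for a weaker effect at the one concentration tested and lower numbers for a stronger effect), where compound 1 gives 5.9%. Two further compounds stand beside it. Compound 2 `C=CCO[C@H]1O[C@H](CN)[C@@H](OCc2ccc3ccccc3c2)[C@H](OCc2ccc3ccccc3c2)[C@H]1N` gives 28.3% in this assay, and compound 3 `C=CCO[C@H]1O[C@H](CN)[C@@H](OCCCc2ccc3ccccc3c2)[C@H](OCCCc2ccc3ccccc3c2)[C@H]1N` gives 7% in this assay. Compound 1 thus holds the lowest of the three numbers, but compound 3 lies within the scatter of it, so the two cannot be told apart; only compound 2 sits beyond the scatter, its number being higher than that of compound 1.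

Compound 4 `CCCCCCCCCO[C@@H]1[C@@H](N)[C@@H](OC[C@@H](O)CN)O[C@H](CN)[C@H]1OCCCCCCCCC` has not yet been measured in this assay. It differs from compound 1 in one place: 2-amino-1-hydroxyethyl in place of 2-azido-1-hydroxyethyl on a saturated chain carbon bound to an oxygen on a saturated carbon. The rest of the shared core is untouched.

Going by the values given here, no step between measured compounds shows what this change does, so the expectation rests on compound 1 alone. Because compound 1 gives 5.9%, compound 4 is expected to land near it, with a step of a number 6.1 percentage points higher from compound 1 to compound 4 (within the scatter) that is expected to stay within or only slightly beyond the scatter, towards a higher number if anywhere. Compound 4 is therefore estimated at 12% in this assay, within a range from 3% to 35%.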

Compound 4, a percentage reported as activity, at one concentration (the size of the read-out at that concentration, not a potency): 7.2%
For compound 4 the middle estimate is 4.8 percentage points above the measured one, within the range that was stated.
By their numbers in this assay, from the lowest: compounds 1, 3 and 4 (each within the scatter of the next); then compound 2.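

Going by these compounds alone, the exchange of 2-azido-1-hydroxyethyl for 2-amino-1-hydroxyethyl, on a saturated chain carbon bound to an oxygen on a saturated carbon, gives the first direct reading of a change at this place. In this assay it produces a number 1.3 percentage points higher from compound 1 to compound 4 (within the scatter), so the two compounds cannot be told apart, and at this concentration the read-out does not distinguish the azide from the amine. Compound 2 and compound 3 could not show this, as each differs from compound 1 in more than one place, and nothing measured here accounts for the outcome of this change.

Still open, as far as these compounds go, is whether a different group at this place, such as a carboxylic acid, an acetamide or a longer chain carrying the amine, would also stay within the scatter of compound 1. Also open, from the compounds shown here alone, is whether compound 1 and compound 4 would remain indistinguishable at other concentrations, since a single reading at one concentration gives no potency for either.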